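Swapping a Pyrazole for a Trimethoxyphenyl Group

A few compounds are considered here, and "the series" means these few. Any claim that something is new, unique, unknown or untested is made for them only; others in the source may bear on it.

Compound 2 `Cc1ccc(CNC(=O)c2cccc(C(C)Oc3ccnc(Nc4cnn(C)c4)c3)c2)cc1` has been tested in a functional assay on HCC78 cells (Homo sapiens) for antiproliferative activity, read by MTT assay, with a stated time of 48 h (a higher number here means a weaker inhibitor, a lower number a stronger inhibitor), where compound 2 gives 8900 nM. Among the two compounds measured so far this is the higher of the two numbers, though only by a hair: its nearest neighbour, compound 1 `CC(Oc1ccnc(Nc2cnn(C)c2)c1)c1cccc(C(=O)NCc2ccc(C#N)cc2)c1`, gives 8700 nM, and the step of a 1.0-fold higher number from compound 1 to compound 2 (0.01 log units; within the scatter) lies within the ordinary scatter of the assay. Compound 3 `COc1cc(Nc2cc(OC(C)c3cccc(C(=O)NCc4ccc(C)cc4)c3)ccn2)cc(OC)c1OC` has not yet been measured. It differs from compound 2 by 3,4,5-trimethoxyphenyl in place of 1-methyl-1H-pyrazol-4-yl on a nitrogen on an aromatic ring. Among the compounds with values here, the only measured step, a 1.0-fold higher number from compound 1 to compound 2 (0.01 log units; within the scatter), concerns a different part of the shared core and says nothing about the amine side, so there is no measured guide for the size or direction of the change from compound 2 to compound 3. For compound 3 the step is therefore estimated as a 1.0-fold higher number from compound 2 to compound 3 (0.00 log units; within the scatter), that is, no change beyond the scatter is expected. On that basis compound 3 is expected to give about 9000 nM, with a wide range from 2000 nM to 40000 nM.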

Compound 3, half-maximal inhibitory concentration: 15700 nM
Beside the measured number, compound 3's estimate is 1.7-fold (0.24 log units) below it; the range from low to high includes it.
By their numbers in this assay, from the lowest: compounds 1, 2 and 3 (each within the scatter of the next).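

In this assay, within the data shown here, this is the first measured step on the amine side of the shared core, and it is a large change in the group: 3,4,5-trimethoxyphenyl, with 12 heavy atoms and a ring of carbon only, in place of 1-methyl-1H-pyrazol-4-yl, with 6 heavy atoms and a ring holding 2 hetero atoms. The result is a 1.8-fold higher number from compound 2 to compound 3 (0.25 log units; within the scatter), so even this exchange on the nitrogen gives no difference that can be told apart from ordinary repeat variation. No measurement available here bears on the reason for this result.

The compounds shown leave open whether a plain phenyl ring, a morpholine-bearing phenyl ring or a simple methyl on that nitrogen would also stay within the scatter. They also leave open whether the trimethoxyphenyl group would behave the same way with a nitrile in place of the methyl on the benzyl ring.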